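The source may report more compounds than this note shows. Statements on the series, on what has been measured and on what is new or still open speak of the compounds shown alone.

Of the compounds shown here, three have been measured in a functional assay on MIA PaCa-2 cells (Homo sapiens) for inhibition, read by MTT assay, with a stated time of 7 days; on this read-out lower numbers stand for stronger inhibition and higher numbers for weaker inhibition. Compound 1 `CCN(CC)S(=O)(=O)c1ccc(S(=O)(=O)N2CCC[C@@H](C(=O)NC3CN(S(C)(=O)=O)C3)C2)cc1` gives 2500 nM. Compound 2 `CC(C)c1noc(N2CCN(C(=O)[C@@H]3CCCN(S(=O)(=O)c4ccc(S(=O)(=O)C5CCC5)cc4)C3)CC2)n1` gives 70 nM, and compound 3 `CCOC(=O)[C@@H]1CCC[C@@H](S(=O)(=O)c2ccc(S(=O)(=O)N(CC)CC)cc2)C1` gives 16400 nM. Among these three numbers compound 1 stands second highest: compound 3 lies well above it, and compound 2 lies far below it, both gaps being wider than the usual scatter of repeated measurements. Neither compound 2 nor compound 3 differs from compound 1 in a single place, so their values show only where compound 1 sits, not what any one change does.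

Compound 4 `CCN(CC)S(=O)(=O)c1ccc(S(=O)(=O)N2CCC[C@@H](C(=O)NC)C2)cc1` is compound 1 with one change: methyl in place of 1-(methylsulfonyl)azetidin-3-yl on an amide-type nitrogen. The amide nitrogen thus keeps only a methyl where compound 1 carries a ring bearing a methylsulfonyl group. Among the compounds with values here, no pair of measured compounds shows this kind of exchange, so the size of the step cannot be read from the data. Compound 2 carries a larger group on the amide side and gives 70 nM, which hints that shrinking this part may cost potency, though compound 2 also differs elsewhere. For compound 4 the step is expected to be a 2.8-fold higher number from compound 1 to compound 4 (0.45 log units; beyond the scatter), towards a higher number. Compound 4 is therefore estimated at 7000 nM, with a likely range from 2500 nM to 25000 nM.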

Compound 4, half-maximal inhibitory concentration: 8600 nM
For compound 4 the middle estimate is 1.2-fold (0.09 log units) below the measured one; measured number inside the range.
By their numbers in this assay, from the lowest: compound 2; then compound 1; then compounds 4 and 3 (each within the scatter of the next).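

Swapping 1-(methylsulfonyl)azetidin-3-yl for methyl on the amide-type nitrogen gives a 3.4-fold higher number from compound 1 to compound 4 (0.54 log units; beyond the scatter) in this assay. This is a modest change, but it lies beyond the usual scatter of repeated measurements. Within the data shown here, this is the first direct sign that the group on this nitrogen matters, since the earlier compounds differed in several places and could only hint at it. The loss is limited, however: with only a methyl there, compound 4 still gives 8600 nM, so the larger group improves the number without being needed for a measurable effect, and no data on hand explain why the value shifts.

The compounds shown leave open which part of the departing group carries the benefit: an azetidin-3-yl group without its methylsulfonyl, or a longer chain such as propyl on the same nitrogen, would help separate the contribution of the ring from that of the methylsulfonyl group. Also open, as far as these compounds go, is how an amine or a carboxylic acid at this place would behave, and whether the same exchange on a different core would give a step of similar size.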